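A few compounds are considered here, and "the series" means these few. Any claim that something is new, unique, unknown or untested is made for them only; others in the source may bear on it.

Within the data shown here, compound 2 `O=C(CSc1nnnn1-c1ccccc1)N/N=c1/scc(-c2ccc([N+](=O)[O-])cc2)n1-c1ccccc1` is the only compound with a number in an ADME assay on NIH3T3 cells (Mus musculus) for cytotoxicity, read by MTT assay, with a stated time of 24 h; on this read-out higher numbers stand for weaker inhibition and lower numbers for stronger inhibition: compound 2 gives 14.3 ug/mL. Compound 1 `Cc1ccc(-c2cs/c(=N/NC(=O)CSc3nnnn3-c3ccccc3)n2-c2ccccc2)cc1` gives only a limit of the assay in this assay, > 500 ug/mL (the limit of > 500 ug/mL in this assay, at which 1 of the 2 values shown sits). Among the measured compounds shown here, the single measured step is large, an at least 34-fold lower number from compound 1 to compound 2 (1.54 log units; beyond the scatter). Compound 3 `N#Cc1ccc(-c2cs/c(=N/NC(=O)CSc3nnnn3-c3ccccc3)n2-c2ccccc2)cc1` differs from compound 2 by cyano in place of nitro on an aromatic carbon. Cyano replacing nitro is not the change that was measured, so the step from compound 1 to compound 2 is only a loose guide, and a smaller move toward weaker inhibition is expected. Compound 3 is expected to give 60 ug/mL in this assay, in the range 15 ug/mL to 300 ug/mL. That estimate means an expected step of a 4.2-fold higher number from compound 2 to compound 3 (0.62 log units; beyond the scatter).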

Compound 3, half-maximal inhibitory concentration: 453 ug/mL
Estimate against measurement, compound 3: 7.6-fold (0.88 log units) below, and the stated range ends below it.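

Nitro, not merely any replacement for methyl, goes with the low number at this position: in this assay, changing 4-nitrophenyl to 4-cyanophenyl gives a 32-fold higher number from compound 2 to compound 3 (1.50 log units; beyond the scatter). Cyano shows no clear separation from methyl, with an at least 1.1-fold lower number from compound 1 to compound 3 (0.04 log units; that floor lies within the scatter). Compound 1 has only a limit of the assay, so that step is a floor: the limit of > 500 ug/mL in this assay, at which 1 of the 3 values shown sits.

The compounds shown leave open how an amine, a carboxylic acid or a methyl ester at this place would read. They therefore cannot tell whether nitro alone stands out.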